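This account rests on a few compounds, and the source may have more. Where it says the series, first, only, none or still open, it means among the compounds named here.

Measured so far in a functional assay on HEK293 cells for agonist activity at D(4) dopamine receptor (Homo sapiens), read by FLIPR; on this read-out lower numbers stand for an effect already at smaller amounts and higher numbers for an effect only at larger amounts of compound:
compound 1, `CCc1cccc(NC(=O)CN2CCC(c3cccc[n+]3[O-])CC2)c1`, gives 95 nM
compound 2, `O=C(NCN1CCC(c2cccc[n+]2[O-])CC1)c1ccc(F)c(Cl)c1`, gives 63 nM
compound 3, `O=C(NCN1CCC(c2cccc[n+]2[O-])CC1)c1ccc(OC(F)(F)F)c(Cl)c1`, gives 170 nM

Compound 2 stands at the low end of these three numbers. Its gap to compound 1 is within the scatter, so the two cannot be ranked against each other; its gap to compound 3 is beyond the scatter. Among the compounds with values here, the one step among the measured compounds that changes only one place is a 2.7-fold higher number from compound 2 to compound 3 (0.43 log units; beyond the scatter), a modest rise brought about by swapping one substituent on the aromatic ring that sits on the carbonyl carbon.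

Compound 4, `O=C(NCN1CCC(c2cccc[n+]2[O-])CC1)c1cc(Cl)cc(Cl)c1`, is not yet measured. It differs from compound 2 in the same region: 3,5-dichlorophenyl in place of 3-chloro-4-fluorophenyl on a carbonyl carbon. Within the data shown here, no measured step exchanges one halogen pattern on that ring for another, so the only bearing comes from the step just described, which altered the same ring and moved the number modestly upward. On that basis only a small shift is expected for compound 4 in this assay, either way, and likely no more than the scatter, with the estimated step of a 1.4-fold higher number from compound 2 to compound 4 (0.15 log units; within the scatter). Compound 4 is therefore expected to give about 90 nM, within a range from 40 nM to 220 nM.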

Compound 4, half-maximal effective concentration: 45 nM
The estimate for compound 4 lay 2.0-fold (0.30 log units) above the measured number; the range from low to high includes it.
By their numbers in this assay, from the lowest: compounds 4, 2, 1 and 3 (each within the scatter of the next, the first and the last beyond it).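

In this assay the exchange of 3-chloro-4-fluorophenyl for 3,5-dichlorophenyl on the carbonyl carbon whose other neighbour is an amide-type nitrogen gives a step that cannot be ranked (a 1.4-fold lower number from compound 2 to compound 4 (0.15 log units; within the scatter)), so this change of halogen pattern leaves the two compounds level. Within the data shown here, the only earlier change on this ring, trifluoromethoxy in place of fluoro, had moved the number beyond the scatter (a 2.7-fold higher number from compound 2 to compound 3 (0.43 log units; beyond the scatter)), so the new step shows that not every change on this ring shifts the read-out and that the fluoro group of compound 2 can give way to a second chlorine without a measurable change. Nothing in the data explains why these two rings read alike.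
The compounds shown leave open whether any halogen on this ring is needed at all, a question that a plain phenyl group or a methoxyphenyl group on the same carbonyl carbon would address. Also open, on these data alone, is how far other groups on this ring, such as a nitrile or a trifluoromethyl, would stay level with compound 2 or move away from it.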